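The source may report more compounds than this note shows. Statements on the series, on what has been measured and on what is new or still open speak of the compounds shown alone.

Measured in an ADME assay on TZM cells (Homo sapiens) for cytotoxicity; a lower number here means that less compound is tolerated, a higher number that more compound is tolerated:

- Compound 1 `CC(C)c1c(OC2CCCCC2C)cc(Cc2ccc(Cl)cc2)[nH]c1=O`: 109000 nM
- Compound 2 `CC1CCCCC1Oc1cc(CCc2ccccc2)[nH]c(=O)c1I`: > 300000 nM
- Compound 3 `Cc1ccc(Cc2cc(OC3CCCCC3C)c(C(C)C)c(=O)[nH]2)cc1`: 99000 nM

The entry for compound 2 is a limit of the assay and not a number. Compound 2 is the only one of the three at the limit of > 300000 nM in this assay, at which 1 of the 3 values shown sits. Compound 1 and compound 3 both gave actual numbers, so any comparison with compound 2 can only be loose.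

Compound 4 `CC1CCCCC1Oc1cc(CCc2ccccc2)[nH]c(=O)c1Br` differs from compound 2 in one place: bromo in place of iodo on an aromatic carbon. The swap is bromo in place of iodo, on an aromatic carbon para to a phenethyl group.

For the measured compounds named here, only one measured step offers any guidance: a 1.1-fold lower number from compound 1 to compound 3 (0.04 log units; within the scatter). That step is a different swap, methyl in place of chloro, on a different pair of compounds, so it says nothing directly about iodo and bromo. It does show one small exchange on an aromatic carbon staying within the scatter, and on that thin basis no step beyond the scatter is expected in this assay. The estimated step is an at least 1.2-fold lower number from compound 2 to compound 4 (0.07 log units; that floor lies within the scatter). A second reading at the limit would fit this expectation equally well. For compound 4 the estimated value is 250000 nM, with an expected range of 110000 nM to 450000 nM.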

Compound 4, half-maximal cytotoxic concentration: 83100 nM
Estimate against measurement, compound 4: 3.0-fold (0.48 log units) above, outside the stated range (below it).
By their numbers in this assay, from the lowest: compounds 4, 3 and 1 (each within the scatter of the next). At a limit, above all of these: compound 2.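

In this assay, this position on the shared core proves sensitive to a single halogen exchange: bromo in place of iodo gives an at least 3.6-fold lower number from compound 2 to compound 4 (0.55 log units; beyond the scatter). The earlier exchange on an aromatic carbon, a 1.1-fold lower number from compound 1 to compound 3 (0.04 log units; within the scatter), was a different swap at a different place, so this is the first single change among the compounds shown that moves the number beyond the scatter, and it does so with the phenethyl group and the rest of the molecule left unchanged. The step gives only a minimum size, and the full gap stays unknown because compound 2 is recorded as a limit of the assay and not as a number: the limit of > 300000 nM in this assay, at which 1 of the 4 values shown sits.

On these data alone, only iodo and bromo have been compared at this position on this core, so the effect of a nitrile, an amine or a carboxylic acid there remains open. Also open, as far as these compounds go, is whether the same exchange would produce a step of similar size with a longer chain in place of the phenethyl group, since both compounds in this pair carry that group.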